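The source may report more compounds than this note shows. Statements on the series, on what has been measured and on what is new or still open speak of the compounds shown alone.

In a functional assay on KB 3-1 cells (Homo sapiens) for cytotoxicity, read by MTT assay, with a stated time of 68 h (a lower number here means a stronger inhibitor, a higher number a weaker inhibitor), compound 1 `O=C(Nc1cccc(-c2nccs2)c1)C(Cl)Cl` gives only a limit, > 50000 nM, so its standing is the limit of > 50000 nM in this assay, at which 1 of the 3 values shown sits, rather than a number. Compound 2 `COc1cccc(-c2cc(NC(=O)C(Cl)Cl)cc(-c3cccc(OC)c3)c2)c1` likewise returns only a limit in this assay, > 30000 nM, namely (the limit of > 30000 nM in this assay, at which 1 of the 3 values shown sits). Within the data shown here, compound 3 `CCOc1ccccc1-c1cc(NC(=O)C(Cl)Cl)cc(-c2ccccc2OCC)c1` is the one member of the set with a number, 8730 nM in this assay. Among the measured compounds shown here, no two of these three compounds differ in a single place, so no measured step can be drawn between them. Compound 4 `O=C(Nc1cccc(-c2ccccc2)c1)C(Cl)Cl` has not yet been measured and differs from compound 1 by phenyl in place of 1,3-thiazol-2-yl on an aromatic carbon. Since compound 1 is known only as a limit, no step beyond the scatter is expected, an at least 1.2-fold lower number from compound 1 to compound 4 (0.09 log units; that floor lies within the scatter). For compound 4 the estimate in this assay is 40000 nM, between 10000 nM and 100000 nM.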

Compound 4, half-maximal inhibitory concentration: 46800 nM
Compound 4: middle estimate off by 1.2-fold (0.07 log units), on the low side; the measured number falls inside the stated range.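

In this assay, phenyl in place of 1,3-thiazol-2-yl on an aromatic carbon gives an at least 1.0-fold lower number from compound 1 to compound 4 (0.02 log units; that floor lies within the scatter). Going by these compounds, that step is only a floor, and its true size stays unknown, because compound 1 is a limit and not a number: the limit of > 50000 nM in this assay, at which 1 of the 4 values shown sits. Compound 4 nevertheless gives a number rather than a limit, so this position now has a measured value against which a further change can be read.

The compounds shown leave open whether another group at this place, such as an amine or a carboxylic acid, would move the number beyond the scatter.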